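Swapping the Amine Ring for Trifluoromethyl: Solubility Outlook

The source may hold more compounds than are shown below. What is called first, only, known or untested is meant among the compounds shown, and "the series" means these compounds.

Compound 1 `O=C(Nc1ccnnc1)c1cc(N2CCNCC2)ccc1OCc1ccccc1` gives 98000 nM in a physicochemical assay for solubility, measured as kinetic solubility; a lower number here means a less soluble compound, a higher number a more soluble compound.
Compound 2 `O=C(Nc1ccnnc1)c1cc(N2C[C@H]3COC[C@H]3C2)ccc1OCc1ccccc1` gives 57000 nM in this assay.
Compound 3 `C[C@@H]1CN(c2ccc(OCc3ccccc3)c(C(=O)Nc3ccnnc3)c2)C[C@H](C)O1` gives 29000 nM in this assay.

Compound 3 has the lowest number of the three: against compound 2 the step is a 2.0-fold lower number from compound 2 to compound 3 (0.29 log units; within the scatter), and against compound 1 it is a 3.4-fold lower number from compound 1 to compound 3 (0.53 log units; beyond the scatter). Compound 4 `O=C(Nc1ccnnc1)c1cc(C(F)(F)F)ccc1OCc1ccccc1` differs from compound 3 in one place: trifluoromethyl in place of 2,6-dimethylmorpholin-4-yl on an aromatic carbon. Within the data shown here, no measured step makes this change; the measured steps only exchange one ring for another, giving a 1.7-fold lower number from compound 1 to compound 2 (0.24 log units; within the scatter) and a 3.4-fold lower number from compound 1 to compound 3 (0.53 log units; beyond the scatter), both small. On these data alone, removing the ring altogether is untested here, so the expectation rests on compound 3 with added uncertainty. Compound 4 is expected to give 10000 nM in this assay, a step of a 2.9-fold lower number from compound 3 to compound 4 (0.46 log units; beyond the scatter), with a range of 2500 nM to 40000 nM.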

Compound 4, solubility: < 1000 nM
Compound 4 ended at the assay's limit (the forecaster's own chance of this, stated with the estimate: 10%); middle value at least 10-fold (1.00 log units) away from the limit.
By their numbers in this assay, from the lowest: compounds 3, 2 and 1 (each within the scatter of the next, the first and the last beyond it). At a limit, below all of these: compound 4.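

In this assay the change from a ring to trifluoromethyl on this aromatic carbon moves the number much further than any exchange of one ring for another, with an at least 29-fold lower number from compound 3 to compound 4 (1.46 log units; beyond the scatter) and an at least 57-fold lower number from compound 2 to compound 4 (1.75 log units; beyond the scatter) and also an at least 98-fold lower number from compound 1 to compound 4 (1.99 log units; beyond the scatter). Compound 4 stands at a limit and not at a number, so these steps give only the smallest possible size of each change: the limit of < 1000 nM in this assay, at which 1 of the 4 values shown sits. Still open, on these data alone, is how an open-chain amine such as dimethylamino, or a carboxylic acid, would read on this aromatic carbon. Also open, as far as these compounds go, is whether any group without a ring can stay clear of the limit.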